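The source may hold more compounds than are shown below. What is called first, only, known or untested is meant among the compounds shown, and "the series" means these compounds.

In a physicochemical assay for solubility, using the shake flask method, in simulated intestinal fluid, measured as kinetic solubility, with a stated time of 2 h, at 25 degrees C, at pH 6.5 (on this read-out higher numbers stand for higher solubility and lower numbers for lower solubility), three compounds on one shared core have been measured so far. Compound 1 (`Cc1noc(-c2nc(C)c3c(c2N)C(=O)N(Cc2ccccc2F)C3=O)n1`) gives < 5000 nM as a limit of the assay and not a number. Compound 2 (`Cc1noc(-c2nc(C)c3c(c2N)C(=O)N(Cc2ccccc2C(F)(F)F)C3=O)n1`) gives < 5000 nM as a limit too. Compound 3 (`Cc1noc(-c2nc(C)c3c(c2N)C(=O)N(Cc2ccc(OC(F)F)cc2)C3=O)n1`) gives < 5000 nM, which is again a limit, so it has no number of its own. Among the measured compounds shown here, the series so far is marked by the limit of < 5000 nM in this assay, at which 3 of the 3 values shown sit, and nothing in it can be ranked.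

Compound 4 (`Cc1noc(-c2nc(C)c3c(c2N)C(=O)N(Cc2ccc(S(C)(=O)=O)cc2)C3=O)n1`) carries methylsulfonyl in place of the difluoromethoxy of compound 3, on an aromatic carbon, para to a large group (methylsulfonyl in place of difluoromethoxy on an aromatic carbon).

The measured changes nearest to this one are a step that the two limits leave unreadable from compound 1 to compound 3 and a step that the two limits leave unreadable from compound 2 to compound 3, and the remaining one is a step that the two limits leave unreadable from compound 1 to compound 2. None of them has a size, so they offer no magnitude or direction to carry over. No step beyond the scatter can therefore be argued from them, and a further limit is the likeliest report. The expected change is a step that the limit leaves unreadable from compound 3 to compound 4, an estimate that rests on limits alone. For compound 4 the estimated value is 3000 nM, with an expected range from 800 nM to 12000 nM.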

Compound 4, solubility: < 5000 nM
Compound 4 gave a limit, no number; the forecaster's own chance of this, stated with the estimate: 75%; the middle value is on the limit's open side.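

In this assay compound 4 gives < 5000 nM, which is a limit and not a number. The steps from compounds 1, 2 and 3 to compound 4 therefore cannot be read, and the series remains held at a single limit: the limit of < 5000 nM in this assay, at which 4 of the 4 values shown sit. The compounds shown leave open where the actual values of compounds 1, 2, 3 and 4 lie and how these compounds rank.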